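A few compounds are considered here, and "the series" means these few. Any claim that something is new, unique, unknown or untested is made for them only; others in the source may bear on it.

Among the compounds with values here, in a functional assay on the whole organism with Canis familiaris (Canis lupus familiaris) as the target, at a dose of 2 mg/kg by the intravenous route (on this read-out higher numbers stand for a stronger effect at the one dose given and lower numbers for a weaker effect), two compounds have given numbers so far. Compound 1 `Cc1ccn2c(C)c(C)nc2c1OCc1ccccc1` gives 70% in this assay. Compound 2 `Cc1nc2c(OCc3ccccc3)cccn2c1NC=O` gives 3%, the lower of the two, and the gap to compound 1 lies well beyond the usual scatter of repeat measurements. These two compounds differ in more than one place. Their gap therefore says nothing about any single change.

Compound 3 `CCCNc1c(C)nc2c(OCc3ccccc3)cccn12` has not yet been measured. It differs from compound 2 in one place only: propyl in place of formyl on a nitrogen on an aromatic ring. The formyl group is replaced by a propyl chain on the same ring nitrogen.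

Within the data shown here, no measured pair shows this particular change, so the expectation rests on the two numbers alone. Because compound 2 sits at 3%, the step from compound 2 to compound 3 is expected to be a rise beyond the scatter, about a number 32 percentage points higher from compound 2 to compound 3 (beyond the scatter), though a weak result remains possible. Compound 3 is therefore estimated at 35%, in a range from 5% to 70%.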

Compound 3, a percentage reported as inhibition, in the whole organism at one dose (the size of the read-out at that dose, not a potency): 12%
Beside the measured number, compound 3's estimate is 23 percentage points above it; low and high end bracket the measured number.
By their numbers in this assay, from the lowest: compounds 2 and 3 (each within the scatter of the next); then compound 1.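

At this nitrogen on an aromatic ring, replacing formyl with propyl gives, in this assay, a number 9 percentage points higher from compound 2 to compound 3 (within the scatter) and thus no change that can be told from ordinary repeat variation. Within the data shown here, this one-place comparison is the first, and it separates two quite different groups on the same nitrogen: formyl has a double bond and a hydrogen-bond acceptor, while propyl has neither. Here, that exchange leaves the read-out effectively unchanged. No measurement available here explains this result.

Still open, from the compounds shown here alone, is whether a longer chain such as butyl, an acetyl group or a free amine on this nitrogen would give a different number. Also open, going by these compounds, is whether the formyl-to-propyl change would read the same way on another core.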